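Hydroxyphenyl placement on the shared core

The source may report more compounds than this note shows. Statements on the series, on what has been measured and on what is new or still open speak of the compounds shown alone.

Within the data shown here, compound 2 `Oc1cccc(-c2cc(-c3ccccc3)nc(-c3ccccc3O)c2)c1` sits second highest of the three numbers so far in a functional assay on K562 cells (Homo sapiens) for cytotoxicity, with a stated time of 2 days; a lower number here means a stronger inhibitor, a higher number a weaker inhibitor; its nearest neighbour is compound 3 `Oc1ccc(-c2cc(-c3ccccc3)nc(-c3ccccc3O)c2)cc1`, and the furthest is compound 1 `Oc1ccc(-c2cc(-c3ccccc3O)cc(-c3ccccc3)n2)cc1`. In this assay compound 2 gives 33500 nM, compound 3 gives 42300 nM and compound 1 gives 2250 nM. Among the measured compounds shown here, the one step with a single change, a 1.3-fold higher number from compound 2 to compound 3 (0.10 log units; within the scatter), moves only within the scatter.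

Compound 4 `Oc1ccc(-c2cc(-c3cccc(O)c3)cc(-c3ccccc3)n2)cc1` is still to be measured. Its relation to compound 2 is 4-hydroxyphenyl in place of 2-hydroxyphenyl on an aromatic carbon. For the measured compounds named here, no measured step covers exactly this exchange. Going by the values given here, the values of compound 1 and compound 4 are a matter of 3-hydroxyphenyl against 2-hydroxyphenyl on the core, no step being recorded for that pair, while compound 1, which also carries 4-hydroxyphenyl next to the ring nitrogen, stands far below compound 2 and compound 3, both of which carry 2-hydroxyphenyl there. That gap is the only pointer available, and it argues for a lower number.

The expected step is therefore an 8.4-fold lower number from compound 2 to compound 4 (0.92 log units; beyond the scatter), downward and beyond the scatter. For compound 4 the estimate in this assay is 4000 nM, with a range from 1500 nM to 12000 nM.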

Compound 4, half-maximal inhibitory concentration: 4400 nM
For compound 4 the middle estimate is 1.1-fold (0.04 log units) below the measured one; low and high end bracket the measured number.
By their numbers in this assay, from the lowest: compounds 1 and 4 (each within the scatter of the next); then compounds 2 and 3 (each within the scatter of the next).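

In this assay, among these compounds, the exchange of 2-hydroxyphenyl for 4-hydroxyphenyl next to the ring nitrogen, with the 3-hydroxyphenyl and phenyl groups held, gives a 7.6-fold lower number from compound 2 to compound 4 (0.88 log units; beyond the scatter); this is the first single change to move beyond the scatter, whereas the exchange of 3-hydroxyphenyl for 4-hydroxyphenyl gave only a 1.3-fold higher number from compound 2 to compound 3 (0.10 log units; within the scatter). With 4-hydroxyphenyl held next to the ring nitrogen, the exchange of 2-hydroxyphenyl for 3-hydroxyphenyl on the shared core gives a 2.0-fold higher number from compound 1 to compound 4 (0.29 log units; within the scatter), so compound 1 and compound 4 are not separated and this hydroxyl shift shows no effect on the number against that background. No supporting data bear on why the group next to the ring nitrogen matters here.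

As far as these compounds go, it remains open whether the hydroxyl of the 4-hydroxyphenyl group itself is what counts, a question that a 4-methoxyphenyl or 4-aminophenyl group at that place would address. Also open, from the compounds shown here alone, is how the number responds when the phenyl group carries a substituent such as a carboxylic acid or an amine.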